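Isobutyl to cyclopentyl on the most potent compound

A few compounds are considered here, and "the series" means these few. Any claim that something is new, unique, unknown or untested is made for them only; others in the source may bear on it.

Within the data shown here, in a functional assay on HL-60 cells (Homo sapiens) for cytotoxicity, read by MTT assay, with a stated time of 72 h (a lower number here means a stronger inhibitor, a higher number a weaker inhibitor), compound 3 (`COc1ccc(C(=O)n2c(CC(C)C)nc3ccccc32)cc1`) gives 34 nM, the lowest of the three numbers so far. Compound 1 (`COc1ccc(-c2nc3ccccc3n2C(=O)c2cccc3ccccc23)cc1`) gives 146 nM, and compound 2 (`O=C(c1cccc2ccccc12)n1c(C2CCC2)nc2ccccc21`) gives 180 nM. Compound 4 (`COc1ccc(C(=O)n2c(C3CCCC3)nc3ccccc32)cc1`) has not yet been measured. It carries cyclopentyl in place of isobutyl on an aromatic carbon. Among the measured compounds shown here, the one measured step that swaps a group on such a carbon is a 1.2-fold higher number from compound 1 to compound 2 (0.09 log units; within the scatter), with cyclobutyl in place of 4-methoxyphenyl. It stayed within the scatter, though compounds 1 and 2 also differ from compound 3 elsewhere. Going by that step, no change beyond the scatter is expected in this assay. The estimated change is a 1.3-fold higher number from compound 3 to compound 4 (0.12 log units; within the scatter). For compound 4 the expected value is 45 nM, with an estimated range of 16 nM to 130 nM.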

Compound 4, half-maximal inhibitory concentration: 76 nM
Compound 4: the middle estimate sits 1.7-fold (0.23 log units) below what was measured; low and high end bracket the measured number.
By their numbers in this assay, from the lowest: compound 3; then compounds 4, 1 and 2 (each within the scatter of the next, the first and the last beyond it).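

On the aromatic carbon between two ring nitrogen atoms, the swap in this assay gives a 2.2-fold higher number from compound 3 to compound 4 (0.35 log units; beyond the scatter). The other swap shown on such a carbon, a 1.2-fold higher number from compound 1 to compound 2 (0.09 log units; within the scatter), stayed within the scatter, so this position can respond to a change of group, though here only modestly. Nothing available explains the step.

Open, from the compounds shown here alone, is whether an amine or a longer chain on this carbon would match isobutyl. Also open, going by these compounds, is whether cyclopentyl would give a similar step alongside the different group that compounds 1 and 2 carry elsewhere.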